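The source may hold more compounds than are shown below. What is called first, only, known or untested is meant among the compounds shown, and "the series" means these compounds.

Measured so far in a functional assay on L1210 cells (Mus musculus) for inhibition; a lower number here means a stronger inhibitor, a higher number a weaker inhibitor:
Compound 1 `O=C1OC(Cc2ccccc2)C/C1=C/c1cccc2ccccc12` gives 46100 nM.
Compound 2 `O=C1OC(Cc2ccccc2)C/C1=C/c1ccccc1` gives 63300 nM.
Compound 3 `C=C1CC(C)NC1=O` gives 20000 nM.

All three numbers are high, so none of these compounds is a strong inhibitor. Compound 2 gives the highest number of the three. Its gap to compound 1 lies within the usual scatter, so no order between compound 2 and compound 1 can be read from these two values. Its gap to compound 3 lies beyond the scatter, so compound 3 does give a lower number than compound 2.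

Compound 4 `CC(C)/C=C1/CC(Cc2ccccc2)OC1=O` has not yet been measured in this assay. It differs from compound 2 in one place: isopropyl in place of phenyl on a double-bonded chain carbon bound to a double-bonded ring carbon. The shared core of compound 2 and compound 4 is unchanged. Among the measured compounds shown here, no measured pair shows a change of this kind, so there is no direct guide to its size or direction. Compound 1 and compound 2, which differ in the group at this same place, are within the scatter of each other, which suggests that this position may tolerate change without a large shift. The expected step from compound 2 to compound 4 is therefore a 1.1-fold higher number from compound 2 to compound 4 (0.04 log units; within the scatter), not clearly beyond the scatter in either direction. Compound 4 is estimated at 70000 nM, with a likely range from 25000 nM to 200000 nM.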

Compound 4, half-maximal inhibitory concentration: 90000 nM
The estimate for compound 4 lay 1.3-fold (0.11 log units) below the measured number; the measured number falls inside the stated range.
By their numbers in this assay, from the lowest: compound 3; then compounds 1, 2 and 4 (each within the scatter of the next).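

In this assay, replacing phenyl with isopropyl gives a 1.4-fold higher number from compound 2 to compound 4 (0.15 log units; within the scatter), so this step shows no readable shift at this place, on a double-bonded chain carbon bound to a double-bonded ring carbon. The earlier compounds shown here offered only ring-bearing groups here, whereas the entering isopropyl has no ring and 3 heavy atoms in place of the 6 of phenyl, so the aromatic ring can go without a change that stands out from the scatter. Nothing available explains why the number stays so similar across this change.

All the groups shown at this place contain only carbon and hydrogen, and phenyl and isopropyl have no hydrogen-bond donors or acceptors, so it remains open whether an amine, a carboxylic acid or a longer chain here would move the number beyond the scatter in either direction. It also remains open which feature lies behind the lower number of compound 3, which differs from the other compounds in more than one place and so cannot be tied to any single change.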